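A few compounds are considered here, and "the series" means these few. Any claim that something is new, unique, unknown or untested is made for them only; others in the source may bear on it.

In a functional assay on K562 cells (Homo sapiens) for inhibition, read by trypan blue exclusion, with a stated time of 48 h (on this read-out higher numbers stand for weaker inhibition and lower numbers for stronger inhibition), the measured compounds read as follows:
Compound 1 `NC(=O)c1cc(Cl)ccc1NC(=O)/C=C/c1ccccc1Br` gives 10000 nM
Compound 2 `Cc1ccccc1/C=C/C(=O)Nc1ccc(Cl)cc1C(N)=O` gives 9500 nM
Compound 3 `NC(=O)c1cc(Br)ccc1NC(=O)/C=C/c1ccccc1Cl` gives 8100 nM

On these numbers compound 3 at 8100 nM stands level with the other two, since all three lie within the scatter of one another. Compound 4 `Cc1ccc(/C=C/C(=O)Nc2ccc(Br)cc2C(N)=O)cc1` differs from compound 3 by the change 4-methylphenyl in place of 2-chlorophenyl on a double-bonded chain carbon bound to a double-bonded chain carbon and is otherwise the same. Among the measured compounds shown here, no measured compound carries the 4-methylphenyl group. For the measured compounds named here, the one measured step that bears on this is a 1.1-fold lower number from compound 1 to compound 2 (0.02 log units; within the scatter) and it also brings in a methyl, in place of bromo, so no step beyond the scatter is expected. In this assay the expected result is a 1.0-fold lower number from compound 3 to compound 4 (0.01 log units; within the scatter) with no clear direction. Compound 4 is thus expected at 8000 nM within an estimated range from 3500 nM to 18000 nM on this read-out.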

Compound 4, half-maximal inhibitory concentration: > 10000 nM
Compound 4: no number, only a limit; the forecaster's own chance of this, stated with the estimate: 10%; middle value at least 1.2-fold (0.09 log units) from the limit.
By their numbers in this assay, from the lowest: compounds 3, 2 and 1 (each within the scatter of the next).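

In this assay compound 4 gives > 10000 nM, which is a limit and not a number. Placing 4-methylphenyl in place of 2-chlorophenyl gives an at least 1.2-fold higher number from compound 3 to compound 4 (0.09 log units; that floor lies within the scatter), so this first change at this place shows no gain in inhibition, but the true size of the step remains unknown. The reading offers no firmer measure than this: the limit of > 10000 nM in this assay, at which 1 of the 4 values shown sits.

The compounds shown leave open how 4-chlorophenyl or 2-methylphenyl on the core of compound 3 would read. They also leave open what a phenyl ring bearing an amine or a carboxylic acid would give at this place.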